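A few compounds are considered here, and "the series" means these few. Any claim that something is new, unique, unknown or untested is made for them only; others in the source may bear on it.

Measured in a functional assay on blood (Homo sapiens), with a stated time of 60 min, in the presence of a further agent that is not named here; on this read-out lower numbers stand for an effect already at smaller amounts and higher numbers for an effect only at larger amounts of compound:
- compound 1 `CON(C)C(=O)C1(S(=O)(=O)c2ccc(Oc3ccc(OC(F)(F)F)cc3)cc2)CCC2(CCNCC2)C1`: 3700 nM
- compound 2 `O=S(=O)(c1ccc(Oc2ccc(OC(F)(F)F)cc2)cc1)C1CCC2(CCNCC2)C1`: > 15000 nM (a limit of the assay, not a number)
- compound 3 `Nc1ccccc1NC(=O)C1(S(=O)(=O)c2ccc(Oc3ccc(OC(F)(F)F)cc3)cc2)CCC2(CCNCC2)C1`: 900 nM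

Among the numbers shown, compound 3 has the lowest value, 900 nM. Its nearest neighbour lies on the far side of a 4.1-fold lower number from compound 1 to compound 3 (0.61 log units; beyond the scatter).

Compound 4 `O=C(Nc1ccccc1O)C1(S(=O)(=O)c2ccc(Oc3ccc(OC(F)(F)F)cc3)cc2)CCC2(CCNCC2)C1` carries hydroxy in place of amino on an aromatic carbon, ortho to a large group (hydroxy in place of amino on an aromatic carbon).

Among the measured compounds shown here, two measured steps bear on this: a 4.1-fold lower number from compound 1 to compound 3 (0.61 log units; beyond the scatter) and an at least 16-fold lower number from compound 2 to compound 3 (1.22 log units; beyond the scatter). Both introduce the whole (2-aminophenyl) amide, and neither exchanges the amino group itself, so the size of this change is not measured in the series. If the hydroxy analogue keeps the full gain seen in a 4.1-fold lower number from compound 1 to compound 3 (0.61 log units; beyond the scatter), no step appears. If it loses that gain, compound 4 falls back towards compound 1 at 3700 nM.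

A small rise in this assay is therefore expected, most likely not beyond the scatter. The expected step is a 1.7-fold higher number from compound 3 to compound 4 (0.22 log units; within the scatter). For compound 4 the estimate is 1500 nM, with an expected range of 400 nM to 6000 nM.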

Compound 4, half-maximal effective concentration: > 15000 nM
Compound 4: a limit, no number; the forecaster's own chance of this, stated with the estimate: 10%; middle value at least 10-fold (1.00 log units) from the limit.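

In this assay, the amino group on the aromatic carbon, ortho to a large group, proves decisive: hydroxy in its place gives an at least 16-fold higher number from compound 3 to compound 4 (1.22 log units; beyond the scatter), so the gain of compound 3 does not carry over to this close analogue. The (2-hydroxyphenyl)carbamoyl group also fails to match the methoxy(methyl)carbamoyl group, with an at least 4.0-fold higher number from compound 1 to compound 4 (0.60 log units; beyond the scatter), so an aryl amide alone does not secure the effect in this series. Compound 4 stands at a limit of the assay, not a number, and its step to compound 2 cannot be read: the limit of > 15000 nM in this assay, at which 2 of the 4 values shown sit.

Open, going by these compounds, is whether the gain needs a free amine at exactly this carbon. A methylamino group, an aminomethyl group or plain hydrogen there would show how narrow that requirement is.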